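The source may report more compounds than this note shows. Statements on the series, on what has been measured and on what is new or still open speak of the compounds shown alone.

In a functional assay on the whole organism with Rattus norvegicus as the target, read by paw edema, with a stated time of 3 h, at a dose of 100 mg/kg by the oral route (a lower number here means less inhibition, a higher number more inhibition at the dose given (going by the name of the read-out)), compound 3 `Cc1ccc(-c2nc3ccccc3n2CC(=O)N2CCCC2)nc1` gives 14%. Among the three compounds measured so far it stands second highest. Compound 1 `COc1cccc(-c2nc3cc(C)ccc3[nH]2)n1` gives 32%, a number beyond the scatter higher than that of compound 3, while compound 2 `Cc1ccc2[nH]c(-c3cccc(O)n3)nc2c1` gives -6%, a number beyond the scatter lower. Going by the values given here, only one pair of measured compounds differs in a single place, and that step runs from compound 1 to compound 2: a number 38 percentage points lower from compound 1 to compound 2 (beyond the scatter), brought about by hydrogen in place of methyl on an oxygen on an aromatic ring.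

Compound 4 `Cc1ccc(-c2nc3ccccc3n2CC(=O)N2CCN(C)CC2)nc1` has not yet been measured. It differs from compound 3 in one place: 4-methylpiperazin-1-yl in place of pyrrolidin-1-yl on a carbonyl carbon. Among the compounds with values here, the change sits on a carbonyl carbon, a part of the molecule left untouched in the single measured step, which concerned a group on an aromatic ring in compounds 1 and 2. Within the data shown here, no measured step therefore bears directly on this change, and the numbers give no ground for expecting a movement in this assay beyond the scatter in either direction. The estimate for compound 4 is 14%, with a range from -4% to 32%. The step this expectation means, no change at the digits printed from compound 3 to compound 4 (within the scatter), is expected to stay within the scatter.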

Compound 4, a percentage reported as inhibition, in the whole organism at one dose (the size of the read-out at that dose, not a potency): 11%
Beside the measured number, compound 4's estimate is 3 percentage points above it; the range from low to high includes it.
By their numbers in this assay, from the lowest: compound 2; then compounds 4 and 3 (each within the scatter of the next); then compound 1.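

In this assay, exchanging the ring on the carbonyl carbon gives a number 3 percentage points lower from compound 3 to compound 4 (within the scatter), so the two compounds cannot be told apart at this dose. This is new information about a part of the molecule that the earlier step, on a group on an aromatic ring, did not touch: here, a six-membered ring with two hetero atoms and one hydrogen-bond acceptor can replace a five-membered ring with one hetero atom and no hydrogen-bond acceptor without a measurable shift in the inhibition of paw edema. No measurement of any property of these compounds is at hand to explain why the two groups give such similar readings.

On these data alone, both groups are saturated rings joined through nitrogen to the carbonyl carbon, so it remains open whether a morpholin-4-yl ring, an open-chain dimethylamino group or a carboxylic acid at this place would move the number beyond the scatter. Each compound also has a reading at one oral dose and one stated time only, which leaves open how the inhibition would look at other doses.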